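A few compounds are considered here, and "the series" means these few. Any claim that something is new, unique, unknown or untested is made for them only; others in the source may bear on it.

Measured so far in an ADME assay on MRC5 cells (Homo sapiens) for cytotoxicity, read by neutral red uptake; a higher number here means that more compound is tolerated, a lower number that less compound is tolerated:
Compound 1 `O=c1[nH]c(SCc2cccs2)nc2ccccc12` gives > 64000 nM, a limit of the assay.
Compound 2 `O=c1[nH]c(SCc2ccc([N+](=O)[O-])cc2)nc2ccccc12` gives > 64000 nM, also a limit.
Compound 3 `O=c1[nH]c(SCc2ccc([N+](=O)[O-])s2)nc2ccccc12` gives > 64000 nM, again a limit.

Compound 4 `O=c1[nH]c(SCc2ccc([N+](=O)[O-])cc2[N+](=O)[O-])nc2ccccc12` has not yet been measured in this assay. It arises from compound 2 by one change, (nitro in place of hydrogen on an aromatic carbon). Compound 3 arises from compound 1 by the same kind of change, (nitro in place of hydrogen on an aromatic carbon); the surroundings differ, since in compound 4 the nitro group sits on a six-membered aromatic ring of carbon only, ortho to a large group and meta to a nitro group, whereas in compound 3 it sits on a five-membered aromatic ring with one sulfur, next to the ring sulfur, two ring bonds from the ring atom that bears a large group. How the cores of compound 2 and compound 1 differ is not broken down here. The measured step that the two limits leave unreadable from compound 1 to compound 3 cannot be sized because of the limit of > 64000 nM in this assay, at which 3 of the 3 values shown sit. The new step is expected to be a step that the limit leaves unreadable from compound 2 to compound 4, which rests on compound 2 giving > 64000 nM, a limit. Compound 4 is therefore estimated at about 80000 nM, most likely reported again as a limit rather than a number.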

Compound 4, half-maximal cytotoxic concentration: > 64000 nM
Compound 4 ended at the assay's limit; the forecaster's own chance of this, stated with the estimate: 85%; the middle value lies beyond the limit too.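

No size can be read for the change from compound 2 to compound 4, because both compounds, like the others shown, give a limit and not a number: the limit of > 64000 nM in this assay, at which 4 of the 4 values shown sit.

The compounds shown leave open how much of each is actually tolerated, and whether a nitro group in place of hydrogen changes that at all.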